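Pyrazolylbenzamide in place of the cinnamamide: compound 4

A few compounds are considered here, and "the series" means these few. Any claim that something is new, unique, unknown or untested is made for them only; others in the source may bear on it.

Measured compounds in an assay on brain for displacement of a labelled ligand from D(3) dopamine receptor (Rattus norvegicus); a higher number here means a weaker inhibitor, a lower number a stronger inhibitor:
compound 1 `CCCN(CC[C@H]1CC[C@H](NC(=O)/C=C/c2ccccc2Cl)CC1)[C@H]1CCc2nc(N)sc2C1` gives 1.2 nM;
compound 2 `CCCN(CC[C@H]1CC[C@H](NC(=O)/C=C/c2cccc(OC)c2)CC1)[C@H]1CCc2nc(N)sc2C1` gives 9.3 nM;
compound 3 `CCCN(CC[C@H]1CC[C@H](NC(=O)/C=C/c2ccccc2OC)CC1)[C@H]1CCc2nc(N)sc2C1` gives 8.1 nM.

Compound 3 holds the second highest number of the three. Its nearest neighbour is compound 2, and the two lie within the scatter of each other, as a 1.1-fold lower number from compound 2 to compound 3 (0.06 log units; within the scatter) shows. Its furthest neighbour is compound 1, which sits well apart from it: a 6.8-fold higher number from compound 1 to compound 3 (0.83 log units; beyond the scatter), a step beyond the scatter. Among the measured compounds shown here, the only other step measured, a 7.8-fold higher number from compound 1 to compound 2 (0.89 log units; beyond the scatter), is of similar size.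

Compound 4 `CCCN(CC[C@H]1CC[C@H](NC(=O)c2ccccc2-n2cccn2)CC1)[C@H]1CCc2nc(N)sc2C1` differs from compound 3 in one place: 2-(1H-pyrazol-1-yl)phenyl in place of 2-(2-methoxyphenyl)ethenyl on a carbonyl carbon. The three measured steps all concern exchanges on or of the aromatic ring that sits on the ethenyl chain, while the chain itself is kept; none of them removes the double bond or brings a second ring onto the phenyl. For the measured compounds named here, no measured step therefore bears directly on this change, and what is known gives no direction for it. The expectation is left open: a step of either sign within the measured spread is as plausible as none.

On that basis compound 4 is estimated at 12 nM, within the range 3 nM to 50 nM, meaning an expected step of a 1.5-fold higher number from compound 3 to compound 4 (0.17 log units; within the scatter).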

Compound 4, inhibition constant: 2 nM
For compound 4 the middle estimate is 6.0-fold (0.78 log units) above the measured one, and the stated range ends above it.
By their numbers in this assay, from the lowest: compounds 1 and 4 (each within the scatter of the next); then compounds 3 and 2 (each within the scatter of the next).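

In this assay, this carbonyl carbon accepts a group with no double bond outside aromatic rings and with a second aromatic ring: 2-(1H-pyrazol-1-yl)phenyl gives a 4.1-fold lower number from compound 3 to compound 4 (0.61 log units; beyond the scatter) and a 4.7-fold lower number from compound 2 to compound 4 (0.67 log units; beyond the scatter), so the exchange strengthens binding relative to both methoxy cinnamamides. Relative to the 2-(2-chlorophenyl)ethenyl group, the same exchange gives a 1.7-fold higher number from compound 1 to compound 4 (0.22 log units; within the scatter), which leaves that pair unresolved, so the ethenyl chain is not required for a low number in this small set. No measured evidence bears on the origin of these steps.

The change removes the ethenyl chain and adds the pyrazole in one step, so the contribution of each remains unresolved; plain phenyl on the carbonyl carbon would help to separate them. Also open, as far as these compounds go, is how far the result extends to other groups at this place, such as 2-(1H-imidazol-1-yl)phenyl, or to a pyrazole attached through a longer chain.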